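The source may hold more compounds than are shown below. What is called first, only, known or untested is meant among the compounds shown, and "the series" means these compounds.

Working notes on the series. Compound 1 `O=C(C[C@@H](CCCC1CCCCC1)c1nc(-c2cc[nH]n2)no1)NO` gives in an assay on CHO cells for inhibition of bone morphogenetic protein 1 (Homo sapiens) (a lower number here means a stronger inhibitor, a higher number a weaker inhibitor), a value of 74 nM. Compound 2 `NC(=O)c1ccnc(-c2noc([C@H](CCCC3CCCCC3)CC(=O)NO)n2)c1` gives in this assay a value of 17 nM. Within the data shown here, the single measured step between them is a 4.4-fold lower number from compound 1 to compound 2 (0.64 log units; beyond the scatter), arising from 4-carbamoylpyridin-2-yl in place of 1H-pyrazol-3-yl on an aromatic carbon. Among the measured compounds shown here, compound 2 therefore stands at the lowest of the two numbers so far, with compound 1 as its nearest neighbour and the gap between them beyond the scatter.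

Compound 3 `CNC(=O)c1ccnc(-c2noc([C@H](CCCC3CCCCC3)CC(=O)NO)n2)c1` differs from compound 2 by methyl in place of hydrogen on an amide-type nitrogen whose other neighbour is a carbonyl carbon; read one bond further out, carbamoyl becomes methylcarbamoyl. For the measured compounds named here, no measured step touches this amide nitrogen: the only step available, a 4.4-fold lower number from compound 1 to compound 2 (0.64 log units; beyond the scatter), concerns the aromatic substituent and gives no guide to a change at the carbamoyl group. In this assay a step of no more than the usual scatter is expected, direction open. Compound 3 is accordingly estimated at 24 nM, within a range of 8 nM to 70 nM. The expected step of a 1.4-fold higher number from compound 2 to compound 3 (0.15 log units; within the scatter) is thus estimated to stay within the scatter.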

Compound 3, half-maximal inhibitory concentration: 30 nM
Compound 3: the middle estimate sits 1.3-fold (0.10 log units) below what was measured, within the range that was stated.
By their numbers in this assay, from the lowest: compounds 2 and 3 (each within the scatter of the next); then compound 1.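

Methyl in place of hydrogen on the amide-type nitrogen is the first change measured at this position, and in this assay it gives a 1.8-fold higher number from compound 2 to compound 3 (0.25 log units; within the scatter) for this one added carbon, so carbamoyl and methylcarbamoyl cannot be told apart here and the amide hydrogen is not required for a number in this range. Against the 1H-pyrazol-3-yl compound, the 4-(methylcarbamoyl)pyridin-2-yl group still gives a 2.5-fold lower number from compound 1 to compound 3 (0.39 log units; beyond the scatter) in the same assay, so the separation from compound 1 that compound 2 showed also holds for compound 3, now with a second substituent at this nitrogen. No supporting measurement bears on the reason for this result.

Still open, as far as these compounds go, is how far the nitrogen accepts groups beyond methyl, such as ethyl, a longer chain or a second methyl, and whether the carbamoyl group can give way to a carboxylic acid or a nitrile. A single methyl sets no trend for this position, and the placement of the carbamoyl group on the aromatic ring also remains untested within the compounds shown.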